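A Longer Chain on the Sulfur-Bearing Group of Compound 2

A few compounds are considered here, and "the series" means these few. Any claim that something is new, unique, unknown or untested is made for them only; others in the source may bear on it.

Of the compounds shown here, two share a core and have been tested in a functional assay on the whole organism (stomach) with Rattus norvegicus as the target; a higher number here means that more compound is needed for the effect, a lower number that less compound is needed. Compound 1 `CCC/N=C(/NC#N)NCCCCn1nc(-c2ccccc2)ccc1=O` reaches only the limit of this assay, at > 100 mg/kg, which is not a measured number. Within the data shown here, compound 2 `C/N=C(\S)NCCCCn1nc(-c2ccccc2)ccc1=O` gives 28.9 mg/kg in this assay, the only actual number so far. The other result, that of compound 1, sits at a limit (the limit of > 100 mg/kg in this assay, at which 1 of the 2 values shown sits). Among the measured compounds shown here, the single measured step, an at least 3.4-fold lower number from compound 1 to compound 2 (0.53 log units; beyond the scatter), exchanged a whole end group for a smaller one that carries sulfur.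

Compound 3 `C=CCNC(=S)NCCCCn1nc(-c2ccccc2)ccc1=O` keeps that sulfur-bearing group but alters it: a group of 6 heavy atoms (4 carbon, 1 nitrogen, 1 sulfur; no ring) in place of a group of 4 heavy atoms (2 carbon, 1 nitrogen, 1 sulfur; no ring), on an amine nitrogen. For the measured compounds named here, no measured step compares such a lengthening of a chain on this nitrogen, so the one known step offers no guide here. Without a comparable change to lean on, the step is expected to be a 1.0-fold higher number from compound 2 to compound 3 (0.02 log units; within the scatter), staying within the scatter. Compound 3 is therefore estimated at 30 mg/kg, with a range from 12 mg/kg to 80 mg/kg.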

Compound 3, dose for half-maximal effect: > 100 mg/kg
Compound 3: no number, only a limit; the forecaster's own chance of this, stated with the estimate: 15%; at least 3.3-fold (0.52 log units) between middle value and limit.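

The group on this amine nitrogen matters even when the sulfur stays, since this assay shows an at least 3.4-fold higher number from compound 2 to compound 3 (0.53 log units; beyond the scatter). Keeping sulfur in the end group is therefore not enough on its own to retain a measured dose, and of the compounds shown only compound 2, with the group of 4 heavy atoms, gives an actual number. Compound 1 and compound 3 both stand at a limit rather than at a number, so the step between them cannot be read: the limit of > 100 mg/kg in this assay, at which 2 of the 3 values shown sit.

From the compounds shown here alone, how far the true value of compound 3 lies past its limit remains open, and so does the full size of this loss. Also open, going by these compounds, is where along the series the change sets in, for instance whether an ethyl or propyl chain in this group would still give a measurable dose.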